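Working notes: from compound 1 to compound 4 in the series

The compounds below may be only part of what the source reports. "The series", "measured", "known", "first", "only" and "open" are said of these compounds alone.

Measured so far:
compound 1 `Cc1cc(C(=O)O)ccc1CN1CCC[C@H](OC(c2cc(Cl)cc(Cl)c2)C(C)O)[C@@H]1c1ccccc1` gives 5300 nM in an assay on isolated protein for activation of cGMP-dependent protein kinase 1 (Homo sapiens), read by ADP-Glo, with stated times of 30 min and 2 h, in the presence of a further agent that is not named here; a lower number here means that less compound is needed, a higher number that more compound is needed for the effect
compound 2 `Cc1cc(C(=O)O)ccc1CN1CCC[C@H](O[C@H](CO)c2cc(Cl)cc(Cl)c2)[C@@H]1c1ccccc1F` gives 2600 nM in this assay
compound 3 `Cc1cc(C(=O)O)ccc1CN1CCC[C@H](OC(c2cc(Cl)cc(Cl)c2)C(C)(C)O)[C@@H]1c1ccccc1` gives 17000 nM in this assay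

Compound 1 stands second highest of the three numbers in this assay; the value of compound 2 lies below it, beyond the scatter, and that of compound 3 lies above it. Among the measured compounds shown here, the only single-point step among the measured compounds is a 3.2-fold higher number from compound 1 to compound 3 (0.51 log units; beyond the scatter), a modest rise.

Compound 4 `Cc1cc(C(=O)O)ccc1CN1CCC[C@H](O[C@H](CO)c2cccc(Cl)c2)[C@@H]1c1ccccc1` is not yet measured. Its change from compound 1 is a group of 10 heavy atoms (8 carbon, 1 oxygen, 1 chlorine; one six-membered aromatic ring of carbon only) in place of a group of 12 heavy atoms (9 carbon, 1 oxygen, 2 chlorine; one six-membered aromatic ring of carbon only), on an oxygen on a saturated carbon. For the measured compounds named here, no measured step touches the aromatic group or its chlorine count, so the step from compound 1 to compound 3 does not bear on it directly. Compound 2 carries the same hydroxyethyl chain as compound 4 but differs from it in two places, so its value and that of compound 1 show only that the chain itself is tolerated. Going by the values given here, with one chlorine removed and no step of that kind measured, the number for compound 4 is expected to sit near compound 1, probably somewhat higher, with a wide range: an estimated step of a 1.3-fold higher number from compound 1 to compound 4 (0.12 log units; within the scatter) in this assay. The estimate for compound 4 is 7000 nM, between 2500 nM and 20000 nM.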

Compound 4, half-maximal effective concentration: 1300 nM
For compound 4 the middle estimate is 5.4-fold (0.73 log units) above the measured one, and the stated range ends above it.
By their numbers in this assay, from the lowest: compounds 4 and 2 (each within the scatter of the next); then compound 1; then compound 3.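

In this assay, the exchange on this oxygen gives a 4.1-fold lower number from compound 1 to compound 4 (0.61 log units; beyond the scatter), so a group with two chlorines is not required here, and the smaller 1-(3-chlorophenyl)-2-hydroxyethyl group is compatible with a lower number. Among the compounds shown here, this is the first step to touch the aromatic group, whereas the earlier step, a 3.2-fold higher number from compound 1 to compound 3 (0.51 log units; beyond the scatter), changed only the chain, but the new step alters the chlorine count, the chain and the defined stereocentre at once, so the shift cannot be assigned to any one of these. No supporting measurement is available to explain the result.

From the compounds shown here alone, it remains open how much of the step comes from the lost chlorine and how much from the 2-hydroxyethyl chain, a question that a pair differing only in the chlorine count could settle. Also open, going by these compounds, is how far this position tolerates other changes, such as an unsubstituted phenyl ring, a 3-methoxyphenyl group, an amine in place of the hydroxyl, or a longer chain carrying the hydroxyl.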